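This account rests on a few compounds, and the source may have more. Where it says the series, first, only, none or still open, it means among the compounds named here.

Measured compounds:
- compound 1, `Cn1c(N)nc2c1c(=O)n(CC1CC1)c(=O)n2CC1CC1`: 30%
- compound 2, `CC(C)Cn1c(N)nc2c1c(=O)n(CC1CC1)c(=O)n2CC1CC1`: 12%
- compound 3, `Nc1nc2c(c(=O)n(CC3CC3)c(=O)n2CC2CC2)n1S(=O)(=O)c1ccc(Cl)cc1`: 1%

In an assay on isolated protein with dual specificity calcium/calmodulin-dependent 3',5'-cyclic nucleotide phosphodiesterase 1B (Bos taurus) as the target, tested at 100 uM (a higher number here means more inhibition at the concentration tested (going by the name of the read-out), a lower number less inhibition), compound 2 gives 12% and stands second highest of the three numbers; its nearest neighbour is compound 3, and the furthest is compound 1. The step from compound 1 to compound 2 is a number 18 percentage points lower from compound 1 to compound 2 (beyond the scatter), and the step from compound 1 to compound 3 is a number 29 percentage points lower from compound 1 to compound 3 (beyond the scatter).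

Compound 4, `Cc1ccc(S(=O)(=O)n2c(N)nc3c2c(=O)n(CC2CC2)c(=O)n3CC2CC2)cc1`, is not yet measured. It differs from compound 2 in one place: (4-methylphenyl)sulfonyl in place of isobutyl on an aromatic nitrogen. Going by the values given here, the step that bears most directly on this change is the one from compound 2 to compound 3, where a (4-chlorophenyl)sulfonyl took the place of the isobutyl on the same aromatic nitrogen: a number 11 percentage points lower from compound 2 to compound 3 (beyond the scatter). The change to compound 4 brings in a (4-methylphenyl)sulfonyl at that nitrogen instead, so a step of similar size and in the same downward direction is expected, with the number for compound 4 likely settling near the bottom of the range seen so far.

Compound 4 is therefore expected to give 3% in this assay, with a range of -6% to 13%. The expected step from compound 2 to compound 4 is thus a number 9 percentage points lower from compound 2 to compound 4 (within the scatter).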

Compound 4, a percentage reported as inhibition, at one concentration (the size of the read-out at that concentration, not a potency): 9%
The estimate for compound 4 lay 6 percentage points below the measured number; measured number inside the range.
By their numbers in this assay, from the lowest: compounds 3, 4 and 2 (each within the scatter of the next, the first and the last beyond it); then compound 1.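

In this assay, (4-methylphenyl)sulfonyl in place of isobutyl on the aromatic nitrogen gives a number 3 percentage points lower from compound 2 to compound 4 (within the scatter) and so cannot be told apart from isobutyl at this position, although the (4-chlorophenyl)sulfonyl of compound 3 lay beyond the scatter from isobutyl. Within the sulfonyl group, methyl in place of chloro on an aromatic carbon gives a number 8 percentage points higher from compound 3 to compound 4 (within the scatter) and so leaves that exchange unresolved, and the two arylsulfonyl compounds offer no sign that this ring substituent matters. Set against methyl on the same nitrogen, (4-methylphenyl)sulfonyl gives a number 21 percentage points lower from compound 1 to compound 4 (beyond the scatter) so that isobutyl and both arylsulfonyl groups all read beyond the scatter under methyl, but nothing available explains this.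

The compounds shown leave open how a plain hydrogen, an ethyl or a benzyl group on this nitrogen would read, and so whether methyl is the best choice here or merely the smallest of the groups shown. They also leave open whether a methylsulfonyl group would behave like the arylsulfonyl groups, and whether anything changes when the amino group or the two cyclopropylmethyl groups on the shared core are replaced.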